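Three Limits and an Unmeasured Acetylpiperazine Amide

The compounds below may be only part of what the source reports. "The series", "measured", "known", "first", "only" and "open" are said of these compounds alone.

- compound 1 `Cc1cc(C#N)cc(C)c1Oc1nc(Nc2ccc(C#N)cc2)ncc1/C=C/C(=O)NC1CC1`: > 221 nM
- compound 2 `Cc1cc(C#N)cc(C)c1Oc1nc(Nc2ccc(C#N)cc2)ncc1/C=C/C(=O)NCCOCCO`: > 200 nM
- compound 3 `Cc1cc(C#N)cc(C)c1Oc1nc(Nc2ccc(C#N)cc2)ncc1/C=C/C(=O)NCC1CCN(S(C)(=O)=O)CC1`: > 171 nM

All three compounds were tested in an ADME assay on TZM cells (Homo sapiens) for cytotoxicity, with a stated time of 1 days (a lower number here means that less compound is tolerated, a higher number that more compound is tolerated), and none of them gave a number. Compound 3 gives > 171 nM, which is a limit. Compound 1 and compound 2 likewise stand only at the limits shown in the list.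

The next compound is compound 4 `CC(=O)N1CCN(C(=O)/C=C/c2cnc(Nc3ccc(C#N)cc3)nc2Oc2c(C)cc(C#N)cc2C)CC1`, not yet measured in this assay. Its change from compound 3 is 4-acetylpiperazin-1-yl in place of ((1-(methylsulfonyl)piperidin-4-yl)methyl)amino on a carbonyl carbon.

Three measured steps alter the same amide substituent, and none has a readable size. They are a step that the two limits leave unreadable from compound 1 to compound 2, a step that the two limits leave unreadable from compound 1 to compound 3 and a step that the two limits leave unreadable from compound 2 to compound 3. They therefore give no direction for the new change, and none of the three compounds has reached a numerical value. No step beyond the usual scatter is expected in this assay. The expected step is a step that the limit leaves unreadable from compound 3 to compound 4. Compound 4 is estimated at 192 nM, with an expected range of 165 nM to 235 nM, most likely reported again as a limit.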

Compound 4, half-maximal cytotoxic concentration: > 192 nM
Compound 4 ended at the assay's limit; the forecaster's own chance of this, stated with the estimate: 90%; the middle value lies on the limit itself.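

In this assay compound 4 gives > 192 nM, which is a limit. Among the compounds shown here, compound 1, compound 2 and compound 3 also stand only at limits, so no step to compound 4 can be read. The compounds shown leave open whether changing the amide substituent alters cytotoxicity at all.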